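The source may hold more compounds than are shown below. What is called first, only, known or untested is meant among the compounds shown, and "the series" means these compounds.

Measured in a functional assay on HT-1080 cells (Homo sapiens) for antiproliferative activity, read by MTT assay, with a stated time of 72 h; on this read-out higher numbers stand for weaker inhibition and lower numbers for stronger inhibition:

compound 1 `CCOC(=O)c1cc(-c2cc(OC)c(OC)c(OC)c2)c(-c2ccc(OC)cc2)s1`: 8370 nM
compound 2 `CCOC(=O)c1cc(-c2cc(OC)c(OC)c(OC)c2)c(-c2ccc(OC)c([N+](=O)[O-])c2)s1`: 12700 nM
compound 3 `COc1ccc(-c2sccc2-c2cc(OC)c(OC)c(OC)c2)cc1`: 4590 nM

Compound 3 stands against compound 1 by hydrogen in place of ethoxycarbonyl on an aromatic carbon, and the step is a 1.8-fold lower number from compound 1 to compound 3 (0.26 log units; within the scatter). Compound 2 stands against compound 1 by nitro in place of hydrogen on an aromatic carbon, and that step is a 1.5-fold higher number from compound 1 to compound 2 (0.18 log units; within the scatter). Compound 3 gives the lowest of the three numbers, but its step to compound 1 lies within the scatter, so no order between those two is claimed; only its gap to compound 2 lies beyond the scatter.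

Compound 4 `COc1ccc(-c2sccc2-c2cc(OC)c(OC)c(OC)c2)cc1[N+](=O)[O-]` has not been measured in this assay. It stands against compound 3 by nitro in place of hydrogen on an aromatic carbon, which is the same kind of change as from compound 1 to compound 2, at a place described in the same words; the two cores differ as given by hydrogen in place of ethoxycarbonyl on an aromatic carbon.

Within the data shown here, on the single precedent, the expected step is a 1.5-fold higher number from compound 3 to compound 4 (0.18 log units; within the scatter), set beside a 1.5-fold higher number from compound 1 to compound 2 (0.18 log units; within the scatter), resting on the pair compound 1 and compound 2 alone. For compound 4 the estimate in this assay is 6900 nM, expected between 3000 nM and 16000 nM.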

Compound 4, half-maximal inhibitory concentration: 2100 nM
Estimate against measurement, compound 4: 3.3-fold (0.52 log units) above, outside the stated range (below it).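

In this assay, nitro in place of hydrogen on the aromatic carbon ortho to a methoxy group gives a 2.2-fold lower number from compound 3 to compound 4 (0.34 log units; beyond the scatter), so the change does not carry over at the same size from the core of compound 1 to the core of compound 3: the same change on two cores in this assay, a 1.5-fold higher number (0.18 log units; within the scatter) from compound 1 to compound 2 and a 2.2-fold lower number (0.34 log units; beyond the scatter) from compound 3 to compound 4, 3.3-fold (0.52 log units) apart, beyond the scatter of two such steps

Read the other way, hydrogen in place of ethoxycarbonyl gives a 6.0-fold lower number from compound 2 to compound 4 (0.78 log units; beyond the scatter) when the nitro group is present, so that change does not carry over at the same size either: the same change on two cores in this assay, a 1.8-fold lower number (0.26 log units; within the scatter) from compound 1 to compound 3 and a 6.0-fold lower number (0.78 log units; beyond the scatter) from compound 2 to compound 4, 3.3-fold (0.52 log units) apart, beyond the scatter of two such steps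

Both comparisons rest on the same four compounds, so they show one dependence between the nitro and ethoxycarbonyl positions in this assay, not a general rule for the series, and they do not show its cause.

The compounds shown leave open whether an amine or a hydroxyl group in place of the nitro would follow compound 4 on the core without ethoxycarbonyl. They also leave open how a carboxylic acid or an amide in place of ethoxycarbonyl would behave with and without the nitro group.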